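The source may report more compounds than this note shows. Statements on the series, on what has been measured and on what is new or still open speak of the compounds shown alone.

The compounds share one core and differ at an amine nitrogen whose other neighbour is a double-bonded nitrogen. Compound 1 has the structure `CC1CCC(=NNc2c(Cl)cccc2Cl)c2ncc(C(=O)O)c(=O)n21`. In a functional assay on the whole organism with Rattus norvegicus as the target (a higher number here means that more compound is needed for the effect, a lower number that less compound is needed), compound 1 gives > 100 umol/kg, which is a limit of the assay and not a number. For the measured compounds named here, compound 2, with the structure `COc1cc(NN=C2CCC(C)n3c2ncc(C(=O)O)c3=O)cc(OC)c1`, is the only other measured compound; in this assay compound 2 gives 100 umol/kg. Where compound 1 stands is told only by the limit of > 100 umol/kg in this assay, at which 1 of the 2 values shown sits, so no number and no step can be read from it. Compound 3, with the structure `CNN=C1CCC(C)n2c1ncc(C(=O)O)c2=O`, has not yet been measured. Its change from compound 1 is methyl in place of 2,6-dichlorophenyl on an amine nitrogen; by the count shown, the methyl is much the smaller group. Going by the values given here, no step between two measured compounds is available to gauge this change. Compound 3 is therefore expected to show a step that the limit leaves unreadable from compound 1 to compound 3, a step estimated as none beyond the scatter, with a real chance that only a limit is again reported. The estimate for compound 3 in this assay is 150 umol/kg, expected to lie between 50 umol/kg and 500 umol/kg.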

Compound 3, dose for 50% inhibition: > 100 umol/kg
Compound 3: a limit, no number; the forecaster's own chance of this, stated with the estimate: 60%; the middle value does not contradict the limit.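

No step from compound 1 to compound 3 can be read in this assay, because each of the two compounds gives only a limit of the assay and not a number: the limit of > 100 umol/kg in this assay, at which 2 of the 3 values shown sit.

The compounds shown leave open how methyl and 2,6-dichlorophenyl on an amine nitrogen compare in this assay.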